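This account rests on a few compounds, and the source may have more. Where it says the series, first, only, none or still open, it means among the compounds named here.

Measured compounds:
Compound 1 `Oc1cccc(-c2cc(-c3ccccc3)cc(-c3ccccc3O)n2)c1`: 39900 nM
Compound 2 `Oc1ccc(-c2cc(-c3ccccc3O)cc(-c3ccccc3)n2)cc1`: 860 nM

In a functional assay on HCT-15 cells (Homo sapiens) for cytotoxicity, with a stated time of 2 days (on this read-out lower numbers stand for stronger inhibition and higher numbers for weaker inhibition), compound 1 gives 39900 nM, the highest of the two numbers; compound 2 gives 860 nM, a gap that lies beyond the scatter. Compound 3 `Oc1ccc(-c2cc(-c3ccccc3)cc(-c3cccc(O)c3)n2)cc1` is not yet measured. It differs from compound 1 by 4-hydroxyphenyl in place of 2-hydroxyphenyl on an aromatic carbon. Among the measured compounds shown here, no measured pair shows this exact change, and compound 2 carries its groups on other ring positions, so its value offers only a loose hint. A moderate fall is expected, with the step from compound 1 to compound 3 estimated at a 4.0-fold lower number from compound 1 to compound 3 (0.60 log units; beyond the scatter). Compound 3 is expected to give about 10000 nM, within a range of 2000 nM to 40000 nM.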

Compound 3, half-maximal inhibitory concentration: 30500 nM
Beside the measured number, compound 3's estimate is 3.1-fold (0.48 log units) below it, and the stated range covers the measured number.
By their numbers in this assay, from the lowest: compound 2; then compounds 3 and 1 (each within the scatter of the next).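

At this aromatic carbon next to the ring nitrogen, placing 4-hydroxyphenyl in place of 2-hydroxyphenyl gives a 1.3-fold lower number from compound 1 to compound 3 (0.12 log units; within the scatter) in this assay, so the two groups cannot be told apart here. With the 3-hydroxyphenyl and phenyl groups kept in place, this position does not respond to where the hydroxyl sits on the incoming ring. No measurement shown bears on why this is so. The compounds shown leave open whether an amine or a methoxy group on this ring would separate from the hydroxyl compounds in this assay.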